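Halogen swap on the diamino-triazine series: chloro to bromo

The compounds below may be only part of what the source reports. "The series", "measured", "known", "first", "only" and "open" are said of these compounds alone.

Measured so far:
compound 1 `Nc1nc(N)nc(-c2cc(Br)ccc2F)n1` gives 100% in a functional assay on the whole organism with Rattus norvegicus as the target, at a dose of 20 mg/kg by the intraperitoneal route; on this read-out higher numbers stand for more inhibition at the one dose given (going by the name of the read-out) and lower numbers for less inhibition
compound 2 `Nc1nc(N)nc(-c2cc(Br)ccc2Cl)n1` gives 86%

Compound 2 is the lower of the two numbers; the nearest is compound 1, whose step is a number 14 percentage points lower from compound 1 to compound 2 (beyond the scatter). The unmeasured compound 3 `Nc1nc(N)nc(-c2cc(Br)ccc2Br)n1` differs from compound 2 by bromo in place of chloro on an aromatic carbon. Going by the values given here, only one measured step bears on this change, the chloro for fluoro exchange that gave a number 14 percentage points lower from compound 1 to compound 2 (beyond the scatter), a modest drop. A further swap of one halogen for another is therefore expected to give at most a modest step, a number 8 percentage points lower from compound 2 to compound 3 (within the scatter), likely downward. Compound 3 is estimated at 78%, within 55% to 95%.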

Compound 3, a percentage reported as inhibition, in the whole organism at one dose (the size of the read-out at that dose, not a potency): 43%
The estimate for compound 3 lay 35 percentage points above the measured number; the measured number lies below the stated range.
By their numbers in this assay, from the lowest: compound 3; then compound 2; then compound 1.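

At this aromatic carbon, the choice of halogen matters far more than the first pair suggested: in this assay the change from chloro to bromo gives a number 43 percentage points lower from compound 2 to compound 3 (beyond the scatter) and is a large step, whereas the earlier change from fluoro to chloro gave a modest one. Taken together, bromo in place of fluoro gives a number 57 percentage points lower from compound 1 to compound 3 (beyond the scatter) and so the drop across these three halogens is uneven. No measurement here explains the sharp fall.

From the compounds shown here alone, how a methyl group, a methoxy group or an amine would fare at this carbon remains open.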